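This account rests on a few compounds, and the source may have more. Where it says the series, first, only, none or still open, it means among the compounds named here.

Measured so far:
compound 1 `CC1=C(C(=O)Nc2cccc([N+](=O)[O-])c2)C(c2ccc(O)cc2O)NC(N/N=C/c2ccco2)=N1`, 8890 nM;
compound 2 `CC1=C(C(=O)Nc2cccc([N+](=O)[O-])c2)C(c2ccc(O)cc2O)NC(N/N=C/c2cccs2)=N1`, 38200 nM;
compound 3 `CC1=NN(C2=NC(C)=C(C(=O)Nc3cccc([N+](=O)[O-])c3)C(c3ccc(O)cc3O)N2)C(=O)/C1=C/c1ccco1`, > 100000 nM.

All three were tested in a functional assay on HCT-116 cells (Homo sapiens) for inhibition, read by sulforhodamine B assay, with a stated time of 2 days; on this read-out higher numbers stand for weaker inhibition of growth and lower numbers for stronger inhibition of growth. Compound 1 gives 8890 nM in this assay. Compound 2 gives 38200 nM. The change between them is thiophen-2-yl in place of furan-2-yl on a carbon with a double bond to nitrogen, and the step is a 4.3-fold higher number from compound 1 to compound 2 (0.63 log units; beyond the scatter). For compound 3 the result is a limit of the assay and not a number, > 100000 nM; this is the limit of > 100000 nM in this assay, at which 1 of the 3 values shown sits. How the core of compound 3 differs from the core of compound 1 is not broken down here.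

Compound 4 `CC1=NN(C2=NC(C)=C(C(=O)Nc3cccc([N+](=O)[O-])c3)C(c3ccc(O)cc3O)N2)C(=O)/C1=C/c1cccs1` is not yet measured. It differs from compound 3 by thiophen-2-yl in place of furan-2-yl on a double-bonded chain carbon bound to a double-bonded ring carbon. The same kind of change was made from compound 1 to compound 2, though the place around it is different: there the ring sat on a carbon with a double bond to nitrogen, here on a double-bonded chain carbon bound to a double-bonded ring carbon. Since compound 3 already sits at the limit, and the earlier step of a 4.3-fold higher number from compound 1 to compound 2 (0.63 log units; beyond the scatter) raised the number, compound 4 is expected to stay beyond the limit as well, with an estimated step that the limit leaves unreadable from compound 3 to compound 4. The estimate for compound 4 is 250000 nM, within 100000 nM to 800000 nM.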

Compound 4, concentration for 50% growth inhibition: 26500 nM
Compound 4: the middle estimate sits 9.4-fold (0.97 log units) above what was measured; measured number below the stated range.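

In this assay, thiophen-2-yl in place of furan-2-yl on a double-bonded chain carbon bound to a double-bonded ring carbon gives an at least 3.7-fold lower number from compound 3 to compound 4 (0.57 log units; beyond the scatter), so on this core the thiophen-2-yl compound inhibits growth more strongly. On the core of compound 1 the same change weakened inhibition, so in these two pairs its effect does not carry from one core to the other, not even in direction: the same change on two cores in this assay, a 4.3-fold higher number (0.63 log units; beyond the scatter) from compound 1 to compound 2 and an at least 3.7-fold lower number (0.57 log units; beyond the scatter) from compound 3 to compound 4, at least 16-fold (1.20 log units) apart, beyond the scatter of two such steps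

Compound 3 gives a limit of the assay and not a number, so only the smallest possible size of the new step is known, and the two pairs do not show why the direction differs: the limit of > 100000 nM in this assay, at which 1 of the 4 values shown sits.

From the compounds shown here alone, how an amine or a carboxylic acid in place of these two rings would behave on either core stays open. Also open, going by these compounds, is whether furan-2-yl and thiophen-2-yl would again differ, and in which direction, on a third core.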